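Three coumarin-pyrazole diesters measured, a fluorinated analogue estimated

The source may report more compounds than this note shows. Statements on the series, on what has been measured and on what is new or still open speak of the compounds shown alone.

Three compounds have been measured in a functional assay on DU-145 cells (Homo sapiens) for cytotoxicity, read by MTT assay, with a stated time of 48 h; a lower number here means a stronger inhibitor, a higher number a weaker inhibitor:

Compound 1 `CCOC(=O)c1c(-c2c(Cl)c3ccccc3oc2=O)nn(-c2cccc(C)c2)c1C(=O)OCC` gives 32000 nM.
Compound 2 `CCOC(=O)c1c(-c2c(Cl)c3ccccc3oc2=O)nn(-c2ccc(OC)cc2)c1C(=O)OCC` gives 25000 nM.
Compound 3 `COC(=O)c1c(-c2cc3ccccc3oc2=O)nn(-c2ccccc2)c1C(=O)OC` gives 30000 nM.

On these three numbers compound 3 stands second highest; its nearest neighbour is compound 1, a hair above it, and its furthest is compound 2, a little below it, and both gaps lie within the scatter of repeated measurements. In short, the three values cannot be told apart.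

Compound 4 `COC(=O)c1c(-c2cc3ccccc3oc2=O)nn(-c2cccc(F)c2)c1C(=O)OC` differs from compound 3 in one place: fluoro in place of hydrogen on an aromatic carbon. Going by the values given here, no measured pair shows exactly this change. Among the compounds with values here, the one step that touches the same ring is a 1.3-fold lower number from compound 1 to compound 2 (0.11 log units; within the scatter), a swap of one substituent pattern on that ring for another, and it stays within the scatter. With only that to go on, and with all three measured values clustered together, a small substituent change on this ring is expected to leave this assay essentially unchanged, so the expected step from compound 3 to compound 4 is no change at the digits printed from compound 3 to compound 4 (within the scatter), that is, none beyond the scatter.

Compound 4 is therefore estimated at 30000 nM in this assay, with a plausible range from 14000 nM to 65000 nM.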

Compound 4, half-maximal inhibitory concentration: 37000 nM
Compound 4: the middle estimate sits 1.2-fold (0.09 log units) below what was measured; the range from low to high includes it.
By their numbers in this assay, from the lowest: compounds 2, 3, 1 and 4 (each within the scatter of the next).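

In this assay, going by these compounds alone, the change from phenyl to 3-fluorophenyl gives a 1.2-fold higher number from compound 3 to compound 4 (0.09 log units; within the scatter), the first direct comparison here between a bare phenyl ring and one carrying a substituent. The earlier step only swapped one substituted ring for another, whereas this one shows that adding a single fluorine atom at this place, meta to a large group, does not move the number beyond the usual scatter of the assay. No supporting measurement is available to explain why this change leaves the result within the scatter.

Still open, as far as these compounds go, is whether fluoro would behave the same way elsewhere on this ring, or on the core of compound 1, which carries a chlorine and ethyl esters in place of the methyl esters of compound 3. From the compounds shown here alone, it is also open whether a group of a very different kind at this place, such as an amine or a carboxylic acid, would shift the number beyond the scatter, since the single fluorine tested here does not answer that.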